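A few compounds are considered here, and "the series" means these few. Any claim that something is new, unique, unknown or untested is made for them only; others in the source may bear on it.

Going by the values given here, compound 3 `COC(=O)[C@]1(CC=C(C)C)C[C@H](CC=C(C)C)C(C)(C)[C@H](C(=O)C(C)C)C1=O` is the starting point for this step, and its only reading comes from a functional assay on 786-0 cells (Homo sapiens) for cytotoxicity, read by CellTiter-Glo, with a stated time of 5 days; on this read-out lower numbers stand for stronger inhibition and higher numbers for weaker inhibition. In this assay compound 3 stops at the limit > 10000 nM, so no number is known for it. Compound 1 `COC(=O)[C@@]1(CC=C(C)C)C[C@H](CC=C(C)C)C(C)(C)[C@H](C(=O)C(C)C)C1=O` in this assay likewise stops at the limit > 10000 nM. Compound 2 `CC(C)=CC[C@@H]1C[C@H](CC=C(C)C)C(C)(C)[C@@H](C(=O)C(C)C)C1=O` in this assay also stops at the limit > 10000 nM. Among the compounds with values here, the one step that bears on the present change is a step that the two limits leave unreadable from compound 1 to compound 3; its size cannot be read because of the limit of > 10000 nM in this assay, at which 3 of the 3 values shown sit, together with the fact that compounds 1 and 3 differ only in the configuration as drawn. Compound 4 `COC(=O)[C@]1(CC=C(C)C)C[C@H](CC=C(C)C)C(C)(C)[C@@H](C(=O)C(C)C)C1=O` has not been measured; (the two compounds have the same atoms and bonds and differ only in configuration as drawn: 1 of 3 stereo elements differ; a stereocentre at a saturated ring carbon is drawn R in compound 3 and S in compound 4). The change is of the same kind as that between compound 1 and compound 3, where both values sit at the limit, so nothing measured separates one configuration from the other. The step that the limit leaves unreadable from compound 3 to compound 4 is therefore expected to stay unreadable, with compound 4 most likely again reported as a limit because of the limit of > 10000 nM in this assay, at which 3 of the 3 values shown sit. Compound 4 is estimated at 20000 nM, within a range from 7000 nM to 60000 nM.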

Compound 4, half-maximal inhibitory concentration: > 10000 nM
Compound 4: only a limit was reported; the forecaster's own chance of this, stated with the estimate: 85%; the middle value is on the limit's open side.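

Compound 4 adds no readable step: its comparisons with compound 1, compound 2 and compound 3 in this assay all run between limits and cannot be read. The compounds shown leave open whether configuration or the methoxycarbonyl group affects this read-out at all.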